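The compounds below may be only part of what the source reports. "The series", "measured", "known", "first", "only" and "open" are said of these compounds alone.

Measured compounds:
compound 1 `CN(C)CCCN1CCN(CC(=O)Nc2ccc(-c3nc4cc(F)ccc4o3)cc2)CC1` — 9180 nM
compound 2 `Cc1ccc2oc(-c3ccc(NC(=O)CN4CCN(CCCN(C)C)CC4)cc3)nc2c1` — 3160 nM

Among the measured compounds shown here, in a functional assay on HepG2 cells (Homo sapiens) for cytotoxicity, read by MTT assay, with a stated time of 24 h (on this read-out higher numbers stand for weaker inhibition and lower numbers for stronger inhibition), compound 2 holds the lower of the two numbers; the only other compound is compound 1, a 2.9-fold lower number from compound 1 to compound 2 (0.46 log units; beyond the scatter).

Compound 3 `Cc1ccc2oc(-c3ccc(NC(=O)CN4CCN(CCCN(C)C)CC4)c(C)c3)nc2c1` differs from compound 2 by methyl in place of hydrogen on an aromatic carbon. For the measured compounds named here, no measured step bears on this position. Going by the values given here, the one step measured, a 2.9-fold lower number from compound 1 to compound 2 (0.46 log units; beyond the scatter), concerns the substituent of the 5-methyl-1,3-benzoxazol-2-yl group and exchanges fluoro for methyl, whereas here a methyl enters in place of hydrogen on the other ring; that step is therefore only a loose guide to how a single methyl can move this read-out. For compound 3 a change within the scatter is expected in either direction, so a 1.0-fold higher number from compound 2 to compound 3 (0.01 log units; within the scatter) is the expected step. The estimate for compound 3 is 3200 nM, with a range from 1100 nM to 9500 nM.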

Compound 3, half-maximal inhibitory concentration: 5650 nM
For compound 3 the middle estimate is 1.8-fold (0.25 log units) below the measured one; the range from low to high includes it.
By their numbers in this assay, from the lowest: compounds 2, 3 and 1 (each within the scatter of the next, the first and the last beyond it).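

In this assay, methyl in place of hydrogen on the aromatic carbon ortho to a large group and meta to a 5-methyl-1,3-benzoxazol-2-yl group gives a 1.8-fold higher number from compound 2 to compound 3 (0.25 log units; within the scatter), so a single methyl is tolerated here without a shift that can be told from the scatter. The earlier step, a 2.9-fold lower number from compound 1 to compound 2 (0.46 log units; beyond the scatter), exchanged fluoro for methyl at another place and gave no reading on this ring, which this result now supplies. Nothing measured on these compounds accounts for the outcome at this carbon.

Still open, on these data alone, is whether a larger or different group on this carbon, such as methoxy, chloro or an amine, would move the number beyond the scatter. Also open, as far as these compounds go, is whether the added methyl would read the same with the fluoro of compound 1 in place of the methyl of compound 2.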